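This account rests on a few compounds, and the source may have more. Where it says the series, first, only, none or still open, it means among the compounds named here.

Compound 1, `CC1=NC(c2cn(S(=O)(=O)c3ccc(Cl)cc3)c3ccccc23)CN1`, gives 5700 nM in an assay on isolated protein for inhibition of kallikrein-7 (Homo sapiens), read by fluorescence, with stated times of 10 min and 30 min; a lower number here means a stronger inhibitor, a higher number a weaker inhibitor.
Compound 2, `CC1=NC(c2cn(S(=O)(=O)c3cccc(Cl)c3)c3ccccc23)CN1`, gives only a limit in this assay, > 30000 nM.
Compound 3, `CC1=NC(c2cn(S(C)(=O)=O)c3ccccc23)CN1`, likewise gives only a limit in this assay, > 100000 nM.

Within the data shown here, compound 1 therefore stands as the only compound of the three with an actual number in this assay; the other two values are limits. The two readable steps both alter the group on the sulfonyl sulfur: an at least 5.2-fold higher number from compound 1 to compound 2 (0.72 log units; beyond the scatter), and an at least 17-fold higher number from compound 1 to compound 3 (1.24 log units; beyond the scatter). The remaining pair gives a step that the two limits leave unreadable from compound 2 to compound 3.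

Compound 4, `CC1=NC(c2cn(S(=O)(=O)c3ccc(Cl)cc3)c3ccc(Br)cc23)CN1`, is not yet measured. It differs from compound 1 by bromo in place of hydrogen on an aromatic carbon. Among the measured compounds shown here, this change sits on the fused ring system of the shared core, not on the sulfonyl sulfur, so none of the measured steps bear directly on it; they show only that the group on the sulfonyl sulfur matters, while nothing in the data speaks to the position changed here. In the absence of any step that tests this position, the expectation for compound 4 in this assay is for no step beyond the scatter, a 1.3-fold lower number from compound 1 to compound 4 (0.10 log units; within the scatter). Compound 4 is thus estimated at 4500 nM, with a range from 1200 nM to 18000 nM.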

Compound 4, half-maximal inhibitory concentration: 4700 nM
For compound 4 the middle estimate is 1.0-fold (0.02 log units) below the measured one, within the range that was stated.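

In this assay, among these compounds, the change on the fused ring system gives a 1.2-fold lower number from compound 1 to compound 4 (0.08 log units; within the scatter), the first reading at a position away from the sulfonyl sulfur. Bromo in place of hydrogen on this aromatic carbon, meta to a fused ring and para to a fused ring, is therefore tolerated in the one case shown, whereas the changes on the sulfonyl sulfur gave an at least 5.2-fold higher number from compound 1 to compound 2 (0.72 log units; beyond the scatter) and an at least 17-fold higher number from compound 1 to compound 3 (1.24 log units; beyond the scatter). No measurement shown here offers a reason why the bromo group leaves the number within the scatter.

On these data alone, one substituent at one position says little about this place in general, so it remains open whether an amine, a carboxylic acid, a methoxy group or a longer chain on the same aromatic carbon would leave the number as undisturbed as bromo does. As far as these compounds go, it also remains open whether bromo would behave the same way with the 3-chlorophenyl or methyl group on the sulfonyl sulfur, and how the other aromatic carbons of the shared core respond to substitution.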